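A few compounds are considered here, and "the series" means these few. Any claim that something is new, unique, unknown or untested is made for them only; others in the source may bear on it.

Measured compounds:
- Compound 1 `C/C(=N\NC(=S)Nc1ccc(I)cc1)c1ccccn1`: 6.61 nM
- Compound 2 `C/C(=N\NC(=S)Nc1ccc(F)cc1)c1ccccn1`: 1.2 nM

In a functional assay on MCF7 cells (Homo sapiens) for cytotoxicity, read by MTT assay, with a stated time of 48 h (on this read-out higher numbers stand for weaker inhibition and lower numbers for stronger inhibition), compound 1 gives 6.61 nM, the higher of the two numbers, and compound 2 gives 1.2 nM. Among the measured compounds shown here, the only measured step, a 5.5-fold lower number from compound 1 to compound 2 (0.74 log units; beyond the scatter), is fluoro in place of iodo on an aromatic carbon.

Compound 3 `C/C(=N/NC(=S)Nc1ccc(I)cc1)c1ccccn1` has not yet been measured in this assay. Its relation to compound 1 is this: the two compounds have the same atoms and bonds and differ only in configuration as drawn: 1 of 1 stereo elements differ; a double bond is drawn E in compound 1 and Z in compound 3. For the measured compounds named here, the halogen step does not bear directly on this change, since no measured pair differs in the configuration of the double bond. With no such evidence, no step beyond the scatter is expected, though the uncertainty is wide in both directions. The estimated step is a 1.2-fold higher number from compound 1 to compound 3 (0.08 log units; within the scatter). For compound 3 the expected value is 8 nM, with an estimated range from 2.5 nM to 25 nM.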

Compound 3, half-maximal inhibitory concentration: 6.61 nM
Estimate against measurement, compound 3: 1.2-fold (0.08 log units) above, and the stated range covers the measured number.
By their numbers in this assay, from the lowest: compound 2; then compounds 1 and 3 (each within the scatter of the next).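

In this assay, turning the double bond from E to Z gives no change at the digits printed from compound 1 to compound 3 (within the scatter). The earlier pair spoke only to the halogen on the aromatic carbon, whereas this one shows that, with iodo in place, the read-out does not separate the two drawn configurations of the double bond. The comparison speaks to that double bond alone, since nothing else varies between the two structures: the fact that compounds 1 and 3 differ only in the configuration as drawn

The compounds shown leave open whether the double bond would matter as little with fluoro in place of iodo, as in compound 2, and so whether the halogen step seen with the E form carries over to the Z form. They also leave open what an amine or a carboxylic acid on that aromatic carbon would do to the read-out in either configuration.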